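Swapping the para group on compound 3 for a tetrazole

The source may report more compounds than this note shows. Statements on the series, on what has been measured and on what is new or still open speak of the compounds shown alone.

Compound 1 `CS(=O)(=O)c1cncc(-c2cnc3ccc(-c4cccc(S(=O)(=O)C5CC5)c4)nn23)c1` gives 18000 nM in a physicochemical assay for solubility, at pH 2; on this read-out higher numbers stand for higher solubility and lower numbers for lower solubility. Compound 2 `NC(=O)c1ccc(-c2cnc3ccc(-c4cccc(S(=O)(=O)C5CC5)c4)nn23)cc1` gives 6300 nM. Compound 3 `C[S+]([O-])c1ccc(-c2cnc3ccc(-c4cccc(S(=O)(=O)C5CC5)c4)nn23)cc1` gives 61000 nM.

Compound 3 stands highest of the three in this assay, above compound 1 by a 3.4-fold higher number from compound 1 to compound 3 (0.53 log units; beyond the scatter) and above compound 2 by a 9.7-fold higher number from compound 2 to compound 3 (0.99 log units; beyond the scatter). Compound 4 `O=S(=O)(c1cccc(-c2ccc3ncc(-c4ccc(-c5nnn[nH]5)cc4)n3n2)c1)C1CC1` differs from compound 3 by a group of 5 heavy atoms (1 carbon, 4 nitrogen; one five-membered aromatic ring with 4 hetero atoms) in place of a group of 3 heavy atoms (1 carbon, 1 oxygen, 1 sulfur; no ring), on an aromatic carbon. The step that bears on this change is a 9.7-fold higher number from compound 2 to compound 3 (0.99 log units; beyond the scatter), where the same position carried a different group and the number moved a good deal. A step of similar size is therefore expected here, most likely downward toward the range of compound 2. The estimate for compound 4 is 8000 nM, between 2000 nM and 30000 nM, a step of a 7.6-fold lower number from compound 3 to compound 4 (0.88 log units; beyond the scatter).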

Compound 4, solubility: < 5000 nM
Compound 4 ended at the assay's limit; the forecaster's own chance of this, stated with the estimate: 10%; at least 1.6-fold (0.20 log units) between middle value and limit.
By their numbers in this assay, from the lowest: compound 2; then compound 1; then compound 3. At a limit, below all of these: compound 4.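

Putting 1H-tetrazol-5-yl on this aromatic carbon gives an at least 12-fold lower number from compound 3 to compound 4 (1.08 log units; beyond the scatter) and so shows that the high number of compound 3 does not carry over to every group at this place. Against carbamoyl the change gives an at least 1.2-fold lower number from compound 2 to compound 4 (0.10 log units; that floor lies within the scatter) and so does not set these two groups apart. In this assay compound 4 sits at a limit and not at a number: the limit of < 5000 nM in this assay, at which 1 of the 4 values shown sits.

Going by these compounds, the true value of compound 4 stays open. So does the number that a carboxylic acid or an aminomethyl group would give at this place on the shared core.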